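Exchanging 3-fluorobenzyl for 4-fluorobenzyl on a shared core

The compounds below may be only part of what the source reports. "The series", "measured", "known", "first", "only" and "open" are said of these compounds alone.

Compound 2 `CC(C)(C)c1cc(/C=C/C(=O)NCCC2CCN(Cc3cccc(F)c3)CC2)cc(C(C)(C)C)c1O` was tested in an assay on isolated protein for inhibition of Amine oxidase [flavin-containing] B (Homo sapiens), read by fluorescence, with stated times of 15 min and 20 min (on this read-out lower numbers stand for stronger inhibition and higher numbers for weaker inhibition), where compound 2 gives 6500 nM. Among the compounds with values here, its only measured neighbour is compound 1 `CC(C)(C)c1cc(/C=C/C(=O)NCCC2CCN(Cc3ccccc3F)CC2)cc(C(C)(C)C)c1O`, which in this assay gives 7400 nM; the step of a 1.1-fold lower number from compound 1 to compound 2 (0.06 log units; within the scatter) lies within the scatter, so although compound 2 holds the lowest of the two numbers, nothing separates it from compound 1 with confidence.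

Compound 3 `CC(C)(C)c1cc(/C=C/C(=O)NCCC2CCN(Cc3ccc(F)cc3)CC2)cc(C(C)(C)C)c1O` has not yet been measured. It differs from compound 2 in one place: 4-fluorophenyl in place of 3-fluorophenyl on a saturated chain carbon bound to an amine nitrogen in a ring. Within the data shown here, the single measured step that bears on this change is a 1.1-fold lower number from compound 1 to compound 2 (0.06 log units; within the scatter), which likewise swapped one fluorophenyl for another on the same saturated chain carbon and produced no shift beyond the scatter. On that basis no step beyond the scatter is expected from compound 2 to compound 3 in this assay, and the expected step is no change at the digits printed from compound 2 to compound 3 (within the scatter). Compound 3 is therefore estimated at 6500 nM in this assay, with an expected range from 2500 nM to 16000 nM.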

Compound 3, half-maximal inhibitory concentration: 11100 nM
The estimate for compound 3 lay 1.7-fold (0.23 log units) below the measured number; low and high end bracket the measured number.
By their numbers in this assay, from the lowest: compounds 2, 1 and 3 (each within the scatter of the next).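

With the 4-fluorophenyl compound read in this assay, the 2-fluorophenyl, 3-fluorophenyl and 4-fluorophenyl groups can now be compared on the saturated chain carbon bound to an amine nitrogen in a ring, and the new pairs give two further steps (a 1.7-fold higher number from compound 2 to compound 3 (0.23 log units; within the scatter) and a 1.5-fold higher number from compound 1 to compound 3 (0.18 log units; within the scatter)). Both steps lie within the scatter, as the earlier step did, so the series still gives no order among the three compounds, and this read-out does not tell the three fluorophenyl groups apart in the shared core. No measurement offered here accounts for the printed numbers, and none is needed to read them as indistinguishable.

What the compounds shown leave open is whether any group at this place would give a step beyond the scatter, since all three carry a fluorophenyl group: an unsubstituted benzyl, a 4-chlorobenzyl or a 4-methoxybenzyl group would each test this. A phenethyl group in place of the fluorobenzyl groups would show in turn whether a longer chain at this place alters the number in this assay.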